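A few compounds are considered here, and "the series" means these few. Any claim that something is new, unique, unknown or untested is made for them only; others in the source may bear on it.

Measured compounds:
compound 1, `C#CCNC(=O)/C=C/c1c(/C=C/c2ccc(OC)cc2)cc(OC)cc1OC`, 6930 nM;
compound 2, `COc1ccc(/C=C/c2cc(OC)cc(OC)c2/C=C/C(=O)N2CCCCC2)cc1`, 10600 nM.

Both were tested in a functional assay on A549 cells (Homo sapiens) for inhibition, read by MTT assay, with a stated time of 48 h; on this read-out lower numbers stand for stronger inhibition and higher numbers for weaker inhibition. Among the measured compounds shown here, compound 1 gives the lowest of the two numbers, but its only neighbour is compound 2, and the step of a 1.5-fold higher number from compound 1 to compound 2 (0.18 log units; within the scatter) stays within the scatter, so the two cannot be ranked against each other. Compound 3, `COc1ccc(/C=C/c2cc(OC)cc(OC)c2/C=C/C(=O)N2CCN(C)CC2)cc1`, has not yet been measured. It differs from compound 1 in one place: 4-methylpiperazin-1-yl in place of propargylamino on a carbonyl carbon. For the measured compounds named here, the only measured step that bears on this is the one from compound 1 to compound 2, where a ring amine also replaced the propargylamino group on the carbonyl carbon, with a 1.5-fold higher number from compound 1 to compound 2 (0.18 log units; within the scatter) as its outcome. Since that step did not move the number beyond the scatter, a similar outcome is expected here: a 1.3-fold higher number from compound 1 to compound 3 (0.11 log units; within the scatter). Compound 3 is therefore estimated at 9000 nM, with a likely range from 4000 nM to 20000 nM.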

Compound 3, half-maximal inhibitory concentration: 4510 nM
Compound 3: the middle estimate sits 2.0-fold (0.30 log units) above what was measured, within the range that was stated.
By their numbers in this assay, from the lowest: compounds 3, 1 and 2 (each within the scatter of the next, the first and the last beyond it).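

In this assay, among the compounds shown here, the change from piperidin-1-yl to 4-methylpiperazin-1-yl on the carbonyl carbon gives the first step at this position to go beyond the scatter, though only modestly (a 2.4-fold lower number from compound 2 to compound 3 (0.37 log units; beyond the scatter)). Two six-membered ring groups in the same place therefore need not read alike, whereas the earlier pair showed no separable difference. The comparison with the open-chain propargylamino group stays within the scatter (a 1.5-fold lower number from compound 1 to compound 3 (0.19 log units; within the scatter)), so compound 3 cannot be ranked against compound 1, and nothing measured here explains the gap between compound 2 and compound 3.

From the compounds shown here alone, it remains open how a morpholin-4-yl ring or a piperazin-1-yl ring without the methyl group would read in this place. Going by these compounds, it is also open whether a longer chain ending in a dimethylamino group would match compound 3.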